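Methoxy for propyl on the carbamate-side chain of compound 3

The source may report more compounds than this note shows. Statements on the series, on what has been measured and on what is new or still open speak of the compounds shown alone.

Compound 3 `CCCCCCCCN1C(=O)[C@H](Cc2ccc(-c3cccc(CN(CCCC)C(=O)OC)c3)cc2)N(C)C(=O)[C@@H]1C` gives 2.7 nM in a functional assay for agonist activity at follicle-stimulating hormone receptor (Homo sapiens), read by a luciferase reporter (a lower number here means that less compound is needed, a higher number that more compound is needed for the effect), the lowest of the three numbers. Compound 2 `CCCCCCN1C(=O)[C@H](Cc2ccc(-c3cccc(CN(CCCC)C(=O)OC)c3)cc2)N(C)C(=O)[C@@H]1C` gives 8.9 nM, and the step of a 3.3-fold lower number from compound 2 to compound 3 (0.52 log units; beyond the scatter) is modest. Compound 1 `CCCCCCCCN1CC(=O)N(C)[C@@H](Cc2ccc(-c3cc(C)c(OC)c(C)c3)cc2)C1=O` gives 1200 nM, far higher, but it differs from compound 3 in several places, so only its two values can be compared.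

Compound 4 `CCCCCCCCN1C(=O)[C@H](Cc2ccc(-c3cccc(CN(COC)C(=O)OC)c3)cc2)N(C)C(=O)[C@@H]1C` differs from compound 3 by methoxy in place of propyl on a saturated chain carbon bound to an amide-type nitrogen. For the measured compounds named here, no measured step touches this position: the one single-point step runs from compound 2 to compound 3 at a saturated chain carbon six bonds along the chain from an amide-type nitrogen in a ring, a different place. Going by the values given here, with no direct precedent, a modest step is expected, most likely toward a higher number, since compound 3 already stands lowest. Compound 4 is therefore estimated at 9 nM, within 2.5 nM to 40 nM, an expected step of a 3.3-fold higher number from compound 3 to compound 4 (0.52 log units; beyond the scatter).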

Compound 4, half-maximal effective concentration: 1.8 nM
Estimate against measurement, compound 4: 5.0-fold (0.70 log units) above; the measured number lies below the stated range.
By their numbers in this assay, from the lowest: compounds 4 and 3 (each within the scatter of the next); then compound 2; then compound 1.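

For the compounds shown here, at this position, the step from butyl to methoxymethyl is the first evidence on the carbamate-side chain, since the earlier single-point step lay elsewhere in the molecule. In this assay the exchange of propyl for methoxy gives a 1.5-fold lower number from compound 3 to compound 4 (0.18 log units; within the scatter) and so leaves the two compounds indistinguishable, showing that this place accepts an oxygen in the chain and a hydrogen-bond acceptor that propyl lacks, without a measurable loss on this one pair. Nothing available accounts for this result.

As far as these compounds go, whether an amine, a carboxylic acid or a longer chain would be accepted at this same place remains open. Also open, from the compounds shown here alone, is whether methoxy in place of propyl would read the same way on the core of compound 2 with its shorter chain.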